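Swapping One Side Group on the Shared Core

The source may report more compounds than this note shows. Statements on the series, on what has been measured and on what is new or still open speak of the compounds shown alone.

Within the data shown here, in a functional assay on KBVIN cells (Homo sapiens) for cytotoxicity, read by MTT assay, with a stated time of 72 h (on this read-out higher numbers stand for an effect only at larger amounts of compound and lower numbers for an effect already at smaller amounts), compound 2 `CCc1cccc2c(OC)c(-c3occ(C)c3C(=S)OC)ccc12` gives 5.1 ug/mL, the higher of the two numbers so far, while compound 1 `CCOC(=O)c1c(C)coc1-c1ccc2c(CC)cccc2c1OC` gives 1.8 ug/mL. Compound 3 `CCc1cccc2c(OC)c(-c3occ(C)c3CO)ccc12` differs from compound 2 on an aromatic carbon: a group of 2 heavy atoms (1 carbon, 1 oxygen; no ring) in place of a group of 4 heavy atoms (2 carbon, 1 oxygen, 1 sulfur; no ring), on an aromatic carbon. Among the measured compounds shown here, the one measured step that bears on this is the modest 2.8-fold higher number from compound 1 to compound 2 (0.45 log units; beyond the scatter), which lies beyond the scatter and was made at that same carbon. It involved a different pair of groups, so it points in no clear direction here. No change beyond the scatter is therefore expected, and the estimated step is a 1.0-fold lower number from compound 2 to compound 3 (0.01 log units; within the scatter). In this assay, compound 3 is expected to give 5 ug/mL, within an estimated range of 2 ug/mL to 14 ug/mL.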

Compound 3, concentration for half-maximal effect: 6.6 ug/mL
Beside the measured number, compound 3's estimate is 1.3-fold (0.12 log units) below it; measured number inside the range.
By their numbers in this assay, from the lowest: compound 1; then compounds 2 and 3 (each within the scatter of the next).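

Putting hydroxymethyl, with its hydrogen-bond donor, in place of the sulfur-containing group gives a 1.3-fold higher number from compound 2 to compound 3 (0.11 log units; within the scatter) in this assay, so this swap at the aromatic carbon cannot be told apart from no effect. Hydroxymethyl in place of ethoxycarbonyl gives a 3.7-fold higher number from compound 1 to compound 3 (0.56 log units; beyond the scatter), which leaves ethoxycarbonyl as the one group of the three that stands apart at this carbon. Nothing measured here offers an explanation for this. As far as these compounds go, whether an amine, a carboxylic acid or a longer chain at this carbon would track ethoxycarbonyl or the other two groups remains open.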